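Amide Replacement on a Nonsecosteroidal Vitamin D Receptor Agonist Scaffold

A few compounds are considered here, and "the series" means these few. Any claim that something is new, unique, unknown or untested is made for them only; others in the source may bear on it.

Measured so far:
compound 1 `CC[C@@H](C)[C@H](NC(=O)c1ccc(C(CC)(CC)c2ccc(OCC(=O)C(C)(C)C)c(C)c2)n1CC)C(=O)OC`, 590 nM
compound 2 `CCOC(=O)CN(C)C(=O)c1ccc(C(CC)(CC)c2ccc(OCC(=O)C(C)(C)C)c(C)c2)n1CC`, > 50000 nM
compound 3 `CC[C@@H](C)[C@H](NC(=O)c1ccc(C(CC)(CC)c2ccc(OCC(O)C(C)(C)C)c(C)c2)n1CC)C(=O)OC`, 26 nM

In an assay on HL-60 cells for agonist activity at vitamin D3 receptor (Homo sapiens), read by microscopy, with a stated time of 96 h (a higher number here means that more compound is needed for the effect, a lower number that less compound is needed), compound 3 gives 26 nM, the lowest of the two numbers shown; its nearest neighbour is compound 1, and a 23-fold lower number from compound 1 to compound 3 (1.36 log units; beyond the scatter), a step that arises when the tert-butyl ketone becomes the 1-hydroxy-2,2-dimethylpropyl group. For compound 2 the assay reports only a limit, (the limit of > 50000 nM in this assay, at which 1 of the 3 values shown sits).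

Compound 4 `CCn1c(C(=O)NCCN(C)C)ccc1C(CC)(CC)c1ccc(OCC(O)C(C)(C)C)c(C)c1` is not yet measured. It differs from compound 3 at the amide: 2-(dimethylamino)ethyl in place of 1-(methoxycarbonyl)-2-methylbutyl on an amide-type nitrogen. For the measured compounds named here, the one measured step that touches the same amide is an at least 84-fold higher number from compound 1 to compound 2 (1.92 log units; beyond the scatter), where the amino acid ester was exchanged for a smaller amide substituent. Compound 4 keeps the amide hydrogen but loses both the ester and the 2-methylbutyl branch, so a large loss is expected, though not necessarily down to the limit reached in an at least 84-fold higher number from compound 1 to compound 2 (1.92 log units; beyond the scatter). The estimate for compound 4 is 600 nM, within 80 nM to 6000 nM, which means an expected 23-fold higher number from compound 3 to compound 4 (1.36 log units; beyond the scatter).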

Compound 4, half-maximal effective concentration: 14 nM
Compound 4: the middle estimate sits 43-fold (1.63 log units) above what was measured; the measured number lies below the stated range.
By their numbers in this assay, from the lowest: compounds 4 and 3 (each within the scatter of the next); then compound 1. At a limit, above all of these: compound 2.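

In this assay the exchange on the amide-type nitrogen gives a 1.9-fold lower number from compound 3 to compound 4 (0.27 log units; within the scatter) and so no change that can be told from the scatter. Until now the only other change shown at this amide was that of compound 2, whose value is a limit of the assay, whereas here the methoxycarbonyl ester, the branched chain and both defined stereocentres leave and the low number stays, with the 1-hydroxy-2,2-dimethylpropyl group present in both compounds. Nothing given here explains why the two substituents read alike.

Going by these compounds, it remains open whether a carboxylic acid or a plain butyl chain on the same nitrogen would read like compound 4. Also open, on these data alone, is whether the 2-(dimethylamino)ethyl group would hold this number alongside the tert-butyl ketone of compound 1.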